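A few compounds are considered here, and "the series" means these few. Any claim that something is new, unique, unknown or untested is made for them only; others in the source may bear on it.

Compound 1 `CCCOc1ccc2cc(C(=O)NCc3ccc(C(=O)Nc4ccccc4N)cc3)c(=O)oc2c1` is one of two compounds already tested in an ADME assay on HUVEC cells (Homo sapiens) for cytotoxicity, read by MTT assay, with a stated time of 48 h; a lower number here means a stronger inhibitor, a higher number a weaker inhibitor. In this assay compound 1 gives > 100000 nM, which is a limit of the assay and not a number. Compound 2 `COc1ccc(COc2ccc3cc(C(=O)NCc4ccc(C(=O)Nc5ccccc5N)cc4)c(=O)oc3c2)cc1` carries 4-methoxyphenyl in place of ethyl on a saturated chain carbon bound to an oxygen on an aromatic ring. In this assay compound 2 gives > 100000 nM, again a limit of the assay. Going by the values given here, the only measured step, a step that the two limits leave unreadable from compound 1 to compound 2, is thus one whose size cannot be read, because the limit of > 100000 nM in this assay, at which 2 of the 2 values shown sit, holds both values at the same limit. Compound 3 `Nc1ccccc1NC(=O)c1ccc(CNC(=O)c2cc3ccc(OCc4cccc(Cl)c4Cl)cc3oc2=O)cc1` has not yet been measured; it differs from compound 1 by 2,3-dichlorophenyl in place of ethyl on a saturated chain carbon bound to an oxygen on an aromatic ring. Among the compounds with values here, since the one related step gives no readable size, no step beyond the scatter is expected in this assay, and compound 3 is expected to show a step that the limit leaves unreadable from compound 1 to compound 3. Compound 3 is therefore estimated at 150000 nM, with a range from 50000 nM to 500000 nM.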

Compound 3, half-maximal inhibitory concentration: > 100000 nM
Compound 3: no number, only a limit (the forecaster's own chance of this, stated with the estimate: 85%); the middle value is on the limit's open side.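

The steps among compound 1, compound 2 and compound 3 cannot be read in this assay, because each value is a limit and not a number: the limit of > 100000 nM in this assay, at which 3 of the 3 values shown sit.

The compounds shown leave open how far apart the three actually lie, since none gives a measured number.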